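Two xanthine amides, and a third

The source may report more compounds than this note shows. Statements on the series, on what has been measured and on what is new or still open speak of the compounds shown alone.

Compound 1 `COc1nc2c(c(=O)n(C)c(=O)n2C)n1CCCC(=O)Nc1ccc(C(C)C)cc1` gives > 200000 nM in an assay on isolated protein for inhibition of high affinity 3',5'-cyclic-AMP phosphodiesterase 7A (Homo sapiens), read by cAMP accumulation, with a stated time of 10 min; a higher number here means a weaker inhibitor, a lower number a stronger inhibitor; this value is a limit of this assay, not a number.
Compound 2 `CCOc1nc2c(c(=O)n(C)c(=O)n2C)n1CCCC(=O)Nc1ccc(C(C)(C)C)cc1` gives 54300 nM in this assay.

Compound 2 thus holds the only number shown in this assay. The other value is a limit: compound 1 sits at the limit of > 200000 nM in this assay, at which 1 of the 2 values shown sits. No pair of measured compounds differs in one place, so no measured step is shown.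

Compound 3 `CCOc1nc2c(c(=O)n(C)c(=O)n2C)n1CCCC(=O)Nc1ccc(C(C)C)cc1` has not been measured in this assay. It differs from compound 2 by hydrogen in place of methyl on a saturated chain carbon bound to an aromatic carbon and two saturated chain carbons. Compound 3 shares its isopropylphenyl amide with compound 1, whose value in this assay is only a limit, so weakening toward that limit is expected.

The step from compound 2 to compound 3 is expected to be a 2.2-fold higher number from compound 2 to compound 3 (0.34 log units; beyond the scatter), a loss beyond the usual scatter. Compound 3 is estimated at 120000 nM, with a range from 40000 nM to 250000 nM.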

Compound 3, half-maximal inhibitory concentration: 96300 nM
The estimate for compound 3 lay 1.2-fold (0.10 log units) above the measured number; measured number inside the range.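

In this assay, tert-butyl to isopropyl on the phenyl amide gives a 1.8-fold higher number from compound 2 to compound 3 (0.25 log units; within the scatter), so at this position the change leaves compound 2 and compound 3 indistinguishable. Within the data shown here, the other change, methyl in place of hydrogen on a saturated chain carbon bound to an oxygen on an aromatic ring, gives an at least 2.0-fold lower number from compound 1 to compound 3 (0.31 log units; beyond the scatter), the only step here beyond the scatter. Going by these compounds, its true size stays unknown, as the value of compound 1 is a limit and not a number: the limit of > 200000 nM in this assay, at which 1 of the 3 values shown sits.

The compounds shown leave open whether a longer chain on that oxygen would continue the step seen from compound 1 to compound 3. They also leave open how an amine or a carboxylic acid in place of the tert-butyl on the phenyl ring would read in this assay.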